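Swapping Phenyl for Dimethylimidazolyl on the Sulfonyl

A few compounds are considered here, and "the series" means these few. Any claim that something is new, unique, unknown or untested is made for them only; others in the source may bear on it.

Measured compounds:
Compound 1, `CCn1c(C(C)NS(=O)(=O)c2ccc(Cl)cc2)nc2cnccc21`: in an ADME assay (liver) for metabolic stability, with Liver microsome (Homo sapiens) as the target, read by LC-MS, using microsomes and NADPH, with a stated time of 5 min, at 37 degrees C (a lower number here means slower removal, a higher number faster removal of the compound), compound 1 gives 35 mL.min-1.g-1.
Compound 2, `CCn1c([C@@H](C)NS(=O)(=O)c2ccccc2)nc2ccc(C(F)(F)F)cc21`: in this assay compound 2 gives 14 mL.min-1.g-1.

Of the two numbers, compound 2 holds the lower one. Its nearest neighbour, compound 1, gives a higher value, and that gap lies beyond the usual scatter of this assay. For the measured compounds named here, the two compounds differ in more than one place, so no single step between them is given here.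

Compound 3, `CCn1c([C@@H](C)NS(=O)(=O)c2cnc(C)n2C)nc2ccc(C(F)(F)F)cc21`, has not yet been measured. It differs from compound 2 in one place: 1,2-dimethyl-1H-imidazol-5-yl in place of phenyl on a sulfonyl sulfur. Going by the values given here, no measured pair covers this change, so the expectation rests on the value of compound 2 alone. In this assay the expected step is small, a 1.3-fold lower number from compound 2 to compound 3 (0.10 log units; within the scatter), not beyond the scatter. Compound 3 is therefore estimated at about 11 mL.min-1.g-1, with a likely range from 5 mL.min-1.g-1 to 24 mL.min-1.g-1.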

Compound 3, intrinsic clearance in microsomes: 58 mL.min-1.g-1
For compound 3 the middle estimate is 5.3-fold (0.72 log units) below the measured one, outside the stated range (above it).
By their numbers in this assay, from the lowest: compound 2; then compounds 1 and 3 (each within the scatter of the next).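

On the sulfonyl sulfur, the choice of ring matters for removal in this assay: 1,2-dimethyl-1H-imidazol-5-yl in place of phenyl gives a 4.1-fold higher number from compound 2 to compound 3 (0.62 log units; beyond the scatter), so this position affects the read-out and the swap moves it towards faster removal. The entering group differs from phenyl in ring size, in carrying hetero atoms and in having 2 hydrogen-bond acceptors against 0, and this single step cannot separate those differences from one another. Nothing available accounts for the step.

Going by these compounds, the finding rests on one pair, so whether it holds on another core remains open. Also open, on these data alone, is how a pyridyl ring, or an imidazole ring without its methyl groups, would read on the same sulfonyl sulfur.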